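The compounds below may be only part of what the source reports. "The series", "measured", "known", "first", "only" and "open" are said of these compounds alone.

Working notes on the series. Going by the values given here, in an assay on isolated protein for inhibition of DNA topoisomerase 1 (Homo sapiens), with a stated time of 30 min, tested at 100 uM (a higher number here means a stronger effect of the compound at the concentration tested, a lower number a weaker effect), compound 1 `Cc1ccc2nc(-c3ccccc3C(F)(F)F)[nH]c(=O)c2c1` gives 72%; its one neighbour, compound 2 `CCN(CC)c1ccc2nc(-c3ccccc3C(F)(F)F)[nH]c(=O)c2c1`, gives 81.7% in this assay, and the two numbers sit within the usual scatter of each other, the one measured step being a number 9.7 percentage points higher from compound 1 to compound 2 (within the scatter). Compound 3 `Cc1ccc2nc(-c3ccccc3F)[nH]c(=O)c2c1` is the next compound and remains to be measured in this assay. It differs from compound 1 in one place: fluoro in place of trifluoromethyl on an aromatic carbon. Among the compounds with values here, the single measured step concerns the other substituent of the shared core and leaves the trifluoromethyl untouched, so nothing measured bears directly on this change; it offers no ground for expecting a step beyond the scatter in either direction. The expected step is therefore small, a number 7 percentage points lower from compound 1 to compound 3 (within the scatter). Compound 3 is expected to give about 65% in this assay, within a range of 45% to 85%.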

Compound 3, a percentage reported as inhibition, at one concentration (the size of the read-out at that concentration, not a potency): 67.9%
Compound 3: middle estimate off by 2.9 percentage points, on the low side, and the stated range covers the measured number.
By their numbers in this assay, from the lowest: compounds 3, 1 and 2 (each within the scatter of the next, the first and the last beyond it).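

On the aromatic carbon of the six-membered aromatic ring of carbon only, ortho to a large group, fluoro in place of trifluoromethyl, with four heavy atoms leaving and one entering, comes out as a number 4.1 percentage points lower from compound 1 to compound 3 (within the scatter) in this assay. This is the first change shown at this position, and the read-out does not separate the two groups, so trifluoromethyl is not required there for an effect of this size at the concentration tested. Nothing available bears on the origin of this result.

The compounds shown leave open whether a different group at this position, such as a methoxy group, a carboxylic acid or a plain hydrogen, would move the read-out beyond the scatter. They also leave open whether fluoro and diethylamino on the shared core would combine to give a larger effect.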